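This account rests on a few compounds, and the source may have more. Where it says the series, first, only, none or still open, it means among the compounds named here.

In a functional assay on HeLa cells (Homo sapiens) for cytotoxicity, read by MTT assay, with a stated time of 48 h (a lower number here means a stronger inhibitor, a higher number a weaker inhibitor), compound 1 `COc1cc(/C=C/C(=O)C2=C(/C=C/c3ccc(O)c(OC)c3)NC(=O)NC2c2ccccc2)ccc1O` gives 100000 nM and compound 2 `COc1cc(/C=C/C(=O)C2=C(/C=C/c3ccc(O)c(OC)c3)NC(=O)NC2c2ccccc2O)ccc1O` gives 50000 nM as its result. Compound 3 `COc1cc(/C=C/C(=O)C2=C(/C=C/c3ccc(O)c(OC)c3)NC(=S)NC2c2ccc(C)cc2)ccc1O` gives 25000 nM as its result, which lies within the scatter of compound 2 but beyond the scatter from compound 1. Compound 4 `COc1cc(/C=C/C(=O)C2=C(/C=C/c3ccc(O)c(OC)c3)NC(=S)NC2c2c(Cl)cccc2Cl)ccc1O` differs from compound 3 in one group: 2,6-dichlorophenyl in place of 4-methylphenyl on a saturated ring carbon. Among the compounds with values here, the only measured step is a 2.0-fold lower number from compound 1 to compound 2 (0.30 log units; within the scatter) for hydroxy in place of hydrogen on an aromatic carbon, and it lies within the scatter. It is a different change and offers only weak guidance, so no step beyond the scatter is expected in this assay in either direction. The expected step is a 1.3-fold lower number from compound 3 to compound 4 (0.10 log units; within the scatter) on this estimate. For compound 4 the estimated value is 20000 nM with an expected range from 6000 nM to 60000 nM as a rough guide.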

Compound 4, half-maximal inhibitory concentration: 100000 nM
Compound 4: middle estimate off by 5.0-fold (0.70 log units), on the low side; measured number above the stated range.
By their numbers in this assay, from the lowest: compounds 3, 2, 1 and 4 (each within the scatter of the next, the first and the last beyond it).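

Replacing 4-methylphenyl with 2,6-dichlorophenyl on the saturated ring carbon gives a 4.0-fold higher number from compound 3 to compound 4 (0.60 log units; beyond the scatter) in this assay. This is the only step shown that lies beyond the scatter, so the group on this ring carbon can measurably change the result, and here the change is towards a weaker inhibitor. No measurement accompanies this step that could explain it. Going by these compounds, it remains open whether the chlorine atoms or their placement matter, and how a phenyl group carrying an amine or a carboxylic acid would behave at this ring carbon.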